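The source may hold more compounds than are shown below. What is called first, only, known or untested is meant among the compounds shown, and "the series" means these compounds.

Measured so far in a functional assay on K562 cells (Homo sapiens) for cytotoxicity, read by MTT assay, with a stated time of 3 days; a lower number here means a stronger inhibitor, a higher number a weaker inhibitor:
- compound 1 `N#Cc1c(NNC(N)=S)nc(SCc2nc3ccccc3[nH]2)nc1-c1ccccc1`: 8.9 nM
- compound 2 `N#Cc1c(NC(N)=O)nc(SCc2nc3ccccc3[nH]2)nc1-c1ccccc1`: 4.54 nM

Among the compounds with values here, compound 2, at 4.54 nM, cannot be told apart from compound 1, the only other compound measured. Compound 3 `N#Cc1c(-c2ccccc2)nc(SCc2nc3ccccc3[nH]2)nc1N1CCNCC1` keeps the shared core and changes one group: piperazin-1-yl in place of ureido on an aromatic carbon. In words, piperazin-1-yl stands in place of ureido on an aromatic carbon. Within the data shown here, the one measured step that bears on this, a 2.0-fold lower number from compound 1 to compound 2 (0.29 log units; within the scatter), replaced one group with no ring by another with no ring. It shows nothing about what happens when a ring enters, so the data give no direction, and no step beyond the scatter is expected in this assay, though the uncertainty is wide. The expected step is a 1.3-fold higher number from compound 2 to compound 3 (0.12 log units; within the scatter). Compound 3 is therefore expected at 6 nM, with an estimated range of 1.5 nM to 30 nM.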

Compound 3, half-maximal inhibitory concentration: 4.38 nM
The estimate for compound 3 lay 1.4-fold (0.14 log units) above the measured number; low and high end bracket the measured number.
By their numbers in this assay, from the lowest: compounds 3, 2 and 1 (each within the scatter of the next, the first and the last beyond it).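

Within the data shown here, at this aromatic carbon, the earlier compounds carried only groups with no ring, and the six-membered non-aromatic ring of piperazin-1-yl now shows that a ring can sit here with a 1.0-fold lower number from compound 2 to compound 3 (0.02 log units; within the scatter) in this assay, so the swap from ureido leaves the number unchanged as far as this assay can tell. Among these compounds, the ring-bearing compound also shows a 2.0-fold lower number from compound 1 to compound 3 (0.31 log units; beyond the scatter) as a modest step, and this is the only gap among the compounds that clears the scatter, since compound 2 lies within the scatter of both others. Nothing measured here explains why the ring is accepted at this position.

The compounds shown leave open whether the second ring nitrogen of piperazin-1-yl matters, which a morpholine ring, with oxygen in that place, would test. A methyl group on that nitrogen, or an open-chain amine in place of the ring, would show whether the ring itself is needed.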